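The source may hold more compounds than are shown below. What is called first, only, known or untested is meant among the compounds shown, and "the series" means these compounds.

In an ADME assay on microsomes from liver (Homo sapiens) for metabolic stability, tested at 2.5 uM (a lower number here means slower removal, a higher number faster removal of the compound), compound 1 `O=S(=O)(c1ccc(F)cc1)c1cnc2cc(F)ccc2c1-c1cccc(F)c1` gives 0.95 mL/min. Compound 2 `COc1ccc(-c2c(S(=O)(=O)c3ccc(F)c(F)c3)cnc3cc(F)ccc23)cc1` gives 1.1 mL/min in this assay, the higher of the two numbers, though the gap to compound 1 lies within the usual scatter, so the two cannot be told apart. Compound 3 `O=S(=O)(c1ccc(F)c(F)c1)c1cnc2cc(F)ccc2c1-c1cccc(F)c1` has not yet been measured in this assay. It differs from compound 2 in one place: 3-fluorophenyl in place of 4-methoxyphenyl on an aromatic carbon. Within the data shown here, no step between measured compounds is available, so the expectation rests on what the two values show. The 3-fluorophenyl that enters is the group already present in compound 1, which gives 0.95 mL/min in this assay, and the two measured values sit within the scatter of each other. The expected step is therefore a 1.1-fold lower number from compound 2 to compound 3 (0.04 log units; within the scatter), which means no change beyond the scatter. Compound 3 is expected to give 1 mL/min in this assay, within a range from 0.5 mL/min to 2 mL/min.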

Compound 3, intrinsic clearance in a liver preparation (reported as CLH), per the amount of preparation that the assay uses: 0.6 mL/min
For compound 3 the middle estimate is 1.7-fold (0.22 log units) above the measured one; low and high end bracket the measured number.
By their numbers in this assay, from the lowest: compounds 3, 1 and 2 (each within the scatter of the next).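

In this assay the aromatic carbon opposite the ring nitrogen now has a measured step, as 3-fluorophenyl in place of 4-methoxyphenyl there gives (a 1.8-fold lower number from compound 2 to compound 3 (0.26 log units; within the scatter)). Swapping one of these substituted phenyl groups for the other therefore does not move the clearance beyond the scatter. The second new step isolates fluoro in place of hydrogen on an aromatic carbon (on a different part of the molecule), and this change also stays within the scatter (a 1.6-fold lower number from compound 1 to compound 3 (0.20 log units; within the scatter)).

As far as these compounds go, all three compounds carry a substituted phenyl at the carbon opposite the ring nitrogen, so it remains open whether an amine, a carboxylic acid or a longer chain there would shift the clearance beyond the scatter. No measurement offers an explanation for either step.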